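The source may report more compounds than this note shows. Statements on the series, on what has been measured and on what is new or still open speak of the compounds shown alone.

Compound 1, whose structure is `CC/C=C/C(=O)Nc1cccc(Oc2nc(Nc3cccc(OC)c3)nc3c2CSCC3)c1`, is the starting point of this series. In a functional assay on MCF7 cells (Homo sapiens) for antiproliferative activity, read by MTT assay, with a stated time of 72 h (on this read-out lower numbers stand for stronger inhibition and higher numbers for weaker inhibition), compound 1 gives 24200 nM. Compound 2, drawn as `CCC/C=C/C(=O)Nc1cccc(Oc2nc(Nc3cccc(OC)c3)nc3c2CSCC3)c1`, differs from compound 1 by methyl in place of hydrogen on a saturated chain carbon, two bonds along the chain from a double-bonded chain carbon, and in this assay compound 2 gives 32000 nM; the step is a 1.3-fold higher number from compound 1 to compound 2 (0.12 log units; within the scatter). Compound 3, drawn as `CC/C=C/C(=O)Nc1cccc(Oc2nc(Nc3ccc(OC)cc3)nc3c2CSCC3)c1`, carries the other variation: 4-methoxyphenyl in place of 3-methoxyphenyl on a nitrogen on an aromatic ring. In this assay compound 3 gives 31400 nM, a step of a 1.3-fold higher number from compound 1 to compound 3 (0.11 log units; within the scatter). The values of compound 2 and compound 3 lie close to each other, neither separated from the other beyond the usual scatter.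

Compound 4, with structure `CCC/C=C/C(=O)Nc1cccc(Oc2nc(Nc3ccc(OC)cc3)nc3c2CSCC3)c1`, is not yet measured. It differs from compound 3 by methyl in place of hydrogen on a saturated chain carbon, two bonds along the chain from a double-bonded chain carbon, the same change that separates compound 2 from compound 1, made at the same place on the chain. Because the earlier instance gave a 1.3-fold higher number from compound 1 to compound 2 (0.12 log units; within the scatter), the corresponding step for compound 4 is expected to be a 1.3-fold higher number from compound 3 to compound 4 (0.12 log units; within the scatter), resting on that single precedent. Compound 4 is therefore estimated at 41000 nM in this assay, with an expected range from 20000 nM to 85000 nM, before its result is known.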

Compound 4, half-maximal inhibitory concentration: > 50000 nM
Compound 4: a limit, no number; the forecaster's own chance of this, stated with the estimate: 10%; middle value at least 1.2-fold (0.08 log units) from the limit.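

In this assay compound 4 gives > 50000 nM, which is a limit of the assay and not a number. On that limit, the methyl on the chain gives an at least 1.5-fold higher number from compound 3 to compound 4 (0.20 log units; that floor lies within the scatter), and the move to 4-methoxyphenyl gives an at least 1.5-fold higher number from compound 2 to compound 4 (0.19 log units; that floor lies within the scatter), so each step is known only as a floor and neither floor lies beyond the scatter. This shows no sign that carrying the methyl from the core of compound 1 to the core of compound 3 changes its step, but it does not show that the step carries over unchanged either: the same change on two cores in this assay, a 1.3-fold higher number (0.12 log units; within the scatter) from compound 1 to compound 2 and an at least 1.5-fold higher number (0.20 log units; that floor lies within the scatter) from compound 3 to compound 4; the limit leaves it open whether they differ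

The compounds shown leave open how the series would read in this assay with a hexenyl chain, or with an amine or a carboxylic acid on the chain in place of the methyl. They also leave open what a fluorine or a hydroxyl in place of the methoxy group on the aromatic ring would do.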